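A few compounds are considered here, and "the series" means these few. Any claim that something is new, unique, unknown or untested is made for them only; others in the source may bear on it.

Measured so far:
compound 1, `CN(C)c1ccc(NC(=S)N2CCC(C(O)(c3ccccc3)c3ccccc3)CC2)cc1`, 612 nM
compound 2, `CN(C)S(=O)(=O)c1ccc(NC(=S)N2CCC(C(O)(c3ccccc3)c3ccsc3)CC2)cc1`, 248 nM
compound 3, `COc1ccc(OC(=O)N2CCC(C(O)(c3ccccc3)c3ccccc3)CC2)cc1`, 2680 nM

All three numbers come from a functional assay for antagonist activity at Neuropeptide Y receptor type 2 (Homo sapiens); on this read-out higher numbers stand for weaker inhibition and lower numbers for stronger inhibition. On this read-out compound 3 stands highest of the three: compound 1 gives a lower number, and compound 2 a lower number still, both gaps beyond the usual scatter. Compound 4, `CS(=O)(=O)c1ccc(OC(=O)N2CCC(C(O)(c3ccccc3)c3ccccc3)CC2)cc1`, is not yet measured. It differs from compound 3 in one place: methylsulfonyl in place of methoxy on an aromatic carbon. Going by the values given here, no measured pair shows this same change, so the size of its effect is open. Compound 2, which carries a sulfonyl-bearing group, shows the lowest number, but it also differs from compound 3 elsewhere, so that comparison carries limited weight. A modest shift toward a lower number is expected, a 1.8-fold lower number from compound 3 to compound 4 (0.25 log units; within the scatter). Compound 4 is therefore estimated at 1500 nM, within 450 nM to 5000 nM.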

Compound 4, half-maximal inhibitory concentration: 141 nM
Compound 4: middle estimate off by 11-fold (1.03 log units), on the high side; the measured number lies below the stated range.
By their numbers in this assay, from the lowest: compounds 4 and 2 (each within the scatter of the next); then compound 1; then compound 3.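

In this assay, this position proves highly sensitive: replacing methoxy with methylsulfonyl on the aromatic carbon para to a large group gives a large step (a 19-fold lower number from compound 3 to compound 4 (1.28 log units; beyond the scatter)). This is the only one-place comparison among these compounds, so it is the first direct measure of what this position can do. Nothing measured here explains the size of this step.

As far as these compounds go, it remains open whether methylsulfonyl improves inhibition or methoxy impairs it. A plain hydrogen, a chlorine atom or a nitrile on the same carbon could separate these two readings.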